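Swapping methoxy for methyl on the sulfonamide aryl ring

The source may report more compounds than this note shows. Statements on the series, on what has been measured and on what is new or still open speak of the compounds shown alone.

Going by the values given here, compound 1 `COc1ccc(S(=O)(=O)NCCCNc2nccc(-c3c(-c4cccc(F)c4)nc4sccn34)n2)cc1` gives 5510 nM in a functional assay on A-375 cells (Homo sapiens) for cytotoxicity, read by MTT assay (a lower number here means a stronger inhibitor, a higher number a weaker inhibitor), the higher of the two numbers measured so far. Compound 2 `O=S(=O)(NCCCNc1nccc(-c2c(-c3cccc(F)c3)nc3sccn23)n1)c1ccc(C(F)(F)F)cc1` gives 4090 nM in this assay, and the step of a 1.3-fold lower number from compound 1 to compound 2 (0.13 log units; within the scatter) altered the same aromatic carbon. Compound 3 `Cc1ccc(S(=O)(=O)NCCCNc2nccc(-c3c(-c4cccc(F)c4)nc4sccn34)n2)cc1` differs from compound 1 by methyl in place of methoxy on an aromatic carbon. Among the compounds with values here, that single step is the only one bearing on this change, and it stayed within the scatter. Because the step of a 1.3-fold lower number from compound 1 to compound 2 (0.13 log units; within the scatter) was so small, compound 3 is expected to show a step of only a 1.1-fold lower number from compound 1 to compound 3 (0.04 log units; within the scatter). The estimate for compound 3 is 5000 nM, expected between 2500 nM and 10000 nM.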

Compound 3, half-maximal inhibitory concentration: 8380 nM
Compound 3: middle estimate off by 1.7-fold (0.22 log units), on the low side; the range from low to high includes it.
By their numbers in this assay, from the lowest: compounds 2, 1 and 3 (each within the scatter of the next, the first and the last beyond it).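

Methoxy and methyl on this aromatic carbon can hardly be told apart, with a 1.5-fold higher number from compound 1 to compound 3 (0.18 log units; within the scatter). Trifluoromethyl and methyl can, with a 2.0-fold higher number from compound 2 to compound 3 (0.31 log units; beyond the scatter), the only step at this position beyond the scatter, though a modest one. So the position is not wholly indifferent to its group, but nothing measured here accounts for that gap.

On these data alone, whether an amine or a carboxylic acid on this aromatic carbon would shift the number further remains open. So does the effect of a longer chain in the same place.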